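A few compounds are considered here, and "the series" means these few. Any claim that something is new, unique, unknown or untested is made for them only; others in the source may bear on it.

Compound 1 `O=c1[nH]cc(S(=O)(=O)Nc2ccccc2-c2cn(-c3ccccc3F)nn2)c(=O)[nH]1` gives 10800 nM in a functional assay on SGC-7901 cells (Homo sapiens) for antiproliferative activity, read by MTT assay, with a stated time of 24 h; a higher number here means a weaker inhibitor, a lower number a stronger inhibitor.
Compound 2 `O=c1[nH]cc(S(=O)(=O)Nc2ccccc2-c2cn(-c3cccc(F)c3)nn2)c(=O)[nH]1` reaches only the limit of this assay, > 20000 nM, and so has no number of its own.
Compound 3 `O=c1[nH]cc(S(=O)(=O)Nc2ccc(-c3cn(-c4ccccc4F)nn3)cc2)c(=O)[nH]1` gives 7270 nM in this assay.

All three share a core in which a fluorophenyl group hangs from an aromatic nitrogen. Between compound 1 and compound 2 the change is 3-fluorophenyl in place of 2-fluorophenyl on an aromatic nitrogen, and it produced an at least 1.8-fold higher number from compound 1 to compound 2 (0.26 log units; that floor lies within the scatter). The true size of that step is known only as a floor because of the limit of > 20000 nM in this assay, at which 1 of the 3 values shown sits. How compound 3 differs from compound 1 is not broken down here. The values of compound 3 and compound 1 lie within the usual scatter of each other, so no order between them can be read.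

Compound 4 `O=c1[nH]cc(S(=O)(=O)Nc2ccc(-c3cn(-c4cccc(F)c4)nn3)cc2)c(=O)[nH]1` has not been measured. It stands to compound 3 as compound 2 stands to compound 1: the change is 3-fluorophenyl in place of 2-fluorophenyl on an aromatic nitrogen, the same change at the same place. Resting on the single earlier step of an at least 1.8-fold higher number from compound 1 to compound 2 (0.26 log units; that floor lies within the scatter), compound 4 is expected to give a higher number than compound 3, with the step estimated at a 2.1-fold higher number from compound 3 to compound 4 (0.31 log units; beyond the scatter). Since the earlier change ended at a limit, the outcome for compound 4 may again be only a limit. Compound 4 is expected to give about 15000 nM, within an estimated range from 7000 nM to 35000 nM in this assay.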

Compound 4, half-maximal inhibitory concentration: > 20000 nM
Compound 4 was reported as a limit; the forecaster's own chance of this, stated with the estimate: 35%; middle value at least 1.3-fold (0.12 log units) away from the limit.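

On the core of compound 3, 3-fluorophenyl in place of 2-fluorophenyl on the aromatic nitrogen gave an at least 2.7-fold higher number from compound 3 to compound 4 (0.43 log units; beyond the scatter), so the change points the same way on both cores, and here even the floor of the step lies beyond the scatter. Set side by side in this assay, the two steps compare as follows: the same change on two cores in this assay, an at least 1.8-fold higher number (0.26 log units; that floor lies within the scatter) from compound 1 to compound 2 and an at least 2.7-fold higher number (0.43 log units; beyond the scatter) from compound 3 to compound 4; the limit leaves it open whether they differ This shows that the loss seen with 3-fluorophenyl was not confined to one core, but with only two cores it is no general rule, and neither step has a known true size, since each is a floor and not a measured distance between two numbers: the limit of > 20000 nM in this assay, at which 2 of the 4 values shown sit.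

The compounds shown leave open how a phenyl ring without fluorine, or one carrying an amine or a carboxylic acid, would behave on the same nitrogen, and so whether any group there could bring the number clearly lower than 2-fluorophenyl does. They also leave open whether the advantage of 2-fluorophenyl over 3-fluorophenyl would hold in cell lines other than the one used in this assay.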